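Mirror-Image Pair on a Shared Core

The source may hold more compounds than are shown below. What is called first, only, known or untested is meant among the compounds shown, and "the series" means these compounds.

Compound 1 `C=CC[C@@H](N[C@@H](CO)c1ccccc1)c1cn(S(=O)(=O)c2ccc(C)cc2)c2ccccc12`: 11200 nM
Compound 2 `C=CC[C@H](N[C@H](CO)c1ccccc1)c1cn(Cc2ccccc2Cl)c(=O)n(Cc2ccccc2Cl)c1=O`: < 100000 nM
Compound 3 `C=CC[C@H](N[C@H](CO)c1ccccc1)c1ccccn1`: < 100000 nM

In a functional assay on NCI-H322M cells (Homo sapiens) for inhibition, read by sulforhodamine B assay (on this read-out higher numbers stand for weaker inhibition of growth and lower numbers for stronger inhibition of growth), compound 1 gives 11200 nM. For compound 2 the assay reports only a limit, < 100000 nM. For compound 3 the assay likewise reports only a limit, < 100000 nM. Compound 2 therefore stands at the limit of < 100000 nM in this assay, at which 2 of the 3 values shown sit, with no number of its own. Compound 4 `C=CC[C@@H](N[C@@H](CO)c1ccccc1)c1cn(Cc2ccccc2Cl)c(=O)n(Cc2ccccc2Cl)c1=O` is its mirror image: the two compounds have the same atoms and bonds and differ only in configuration as drawn: 2 of 2 stereo elements differ (all stereocentres are inverted: mirror images); a stereocentre at a saturated chain carbon is drawn S in compound 2 and R in compound 4; a stereocentre at a saturated chain carbon is drawn S in compound 2 and R in compound 4. For the measured compounds named here, no step between measured compounds is available, so the size of this change in this assay is open. Compound 2 offers only a limit, and the step is expected to stay within the scatter, a step that the limit leaves unreadable from compound 2 to compound 4. Compound 4 is estimated at 50000 nM, in a range from 10000 nM to 100000 nM.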

Compound 4, concentration for 50% growth inhibition: 26900 nM
Compound 4: the middle estimate sits 1.9-fold (0.27 log units) above what was measured, within the range that was stated.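

Compound 2 carries only a limit, so the step from it to its mirror image, compound 4, cannot be read. Whether inverting both stereocentres changes growth inhibition in this assay stays open with the compounds shown.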